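Ethyl Gives Way to Phenyl at the End of the Core

The source may hold more compounds than are shown below. What is called first, only, known or untested is meant among the compounds shown, and "the series" means these compounds.

Measured compounds:
compound 1, `CCc1nc2cc(-c3nc4cc(-c5nc6cc(-c7ccccc7)ccc6[nH]5)ccc4[nH]3)ccc2[nH]1`, 110 nM
compound 2, `c1ccc2cc(-c3ccc4[nH]c(-c5ccc6[nH]c(-c7ccc8[nH]cnc8c7)nc6c5)nc4c3)ccc2c1`, 80 nM
compound 3, `c1ccc(-c2cccc3[nH]c(-c4ccc5[nH]c(-c6ccc7[nH]cnc7c6)nc5c4)nc23)cc1`, 7000 nM

In a functional assay on RPMI 8402 cells (Homo sapiens) for cytotoxicity (a higher number here means a weaker inhibitor, a lower number a stronger inhibitor), compound 1 stands second highest of the three numbers. Its nearest neighbour is compound 2, whose number is lower but within the scatter, so the two cannot be told apart. The furthest is compound 3, whose number is higher by a margin well beyond the scatter.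

Compound 4, `c1ccc(-c2ccc3[nH]c(-c4ccc5[nH]c(-c6ccc7[nH]c(-c8ccccc8)nc7c6)nc5c4)nc3c2)cc1`, differs from compound 1 in one place: phenyl in place of ethyl on an aromatic carbon. Within the data shown here, no step between two measured compounds isolates this change, so the expectation rests on the neighbours. Compound 2 carries a fused aromatic group at the end of the shared core and in this assay gives 80 nM, close to compound 1, which suggests a larger aromatic end group is tolerated there. Compound 3 carries its phenyl at a different place and gives 7000 nM, so placement can matter, but compound 4 keeps the place of the ethyl of compound 1.

Compound 4 is therefore expected to give a number near that of compound 1, with a step of a 1.2-fold lower number from compound 1 to compound 4 (0.09 log units; within the scatter) not beyond the scatter, estimated at 90 nM with a range from 30 nM to 300 nM.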

Compound 4, half-maximal inhibitory concentration: 60 nM
Compound 4: middle estimate off by 1.5-fold (0.18 log units), on the high side; measured number inside the range.
By their numbers in this assay, from the lowest: compounds 4, 2 and 1 (each within the scatter of the next); then compound 3.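

Phenyl in place of ethyl on an aromatic carbon, between two ring nitrogen atoms, gives in this assay a direct step at this position: a 1.8-fold lower number from compound 1 to compound 4 (0.26 log units; within the scatter). The earlier compounds shown here offered only indirect hints about this place, whereas this single change shows that ethyl, with 2 heavy atoms and no ring, and phenyl, with 6 heavy atoms and a six-membered aromatic ring, cannot be told apart here, so the added atoms and ring bring no readable difference in this read-out. No measurement is available that could explain this result.

Both groups contain carbon only, with no hydrogen-bond donors or acceptors and no net charge, so the compounds shown leave open how an amine, a carboxylic acid or a hydroxyl group would read at this position. They also leave open whether a longer chain, or a phenyl carrying a substituent such as methoxy, would stay within the scatter of compound 1 or move the number beyond it.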